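Covalent pyrazole series on mantle cell lymphoma cells

The source may report more compounds than this note shows. Statements on the series, on what has been measured and on what is new or still open speak of the compounds shown alone.

Measured compounds:
compound 1 `O=C(CCl)N1CCCC(n2nc(-c3ccc(Oc4ccccc4)cc3)cc2CO)C1` — 7800 nM
compound 2 `C=CC(=O)Nc1cccc(Cn2nc(-c3ccc(Oc4ccccc4)cc3)cc2C(=O)OCC)c1` — 7600 nM
compound 3 `C=CC(=O)N1CCCC(n2nc(-c3ccc(Oc4ccccc4)cc3)cc2C(=O)OCC)C1` — 21200 nM

Of the compounds shown here, three have been measured in a functional assay on JeKo-1 cells (Homo sapiens) for inhibition, read by luminescence and CellTiter-Glo, with a stated time of 72 h; a higher number here means a weaker inhibitor, a lower number a stronger inhibitor. Compound 1 gives 7800 nM, compound 2 gives 7600 nM and compound 3 gives 21200 nM. Compound 2 holds the lowest number of the three, but its gap to compound 1 lies within the scatter, so the two cannot be ranked; only compound 3 stands apart from compound 2 with a higher number beyond the scatter.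

Compound 4 `C/C=C/C(=O)Nc1ccc(Cn2nc(-c3ccc(Oc4ccccc4)cc3)cc2C(=O)OCC)cc1` has not been measured. It differs from compound 2 in one place: 4-(((prop-1-en-1-yl)carbonyl)amino)phenyl in place of 3-((vinylcarbonyl)amino)phenyl on a saturated chain carbon bound to an aromatic nitrogen. Among the compounds with values here, no pair of measured compounds differs in just one place, so no measured step guides this change. The nearest comparison, compound 2 against compound 3, changes more than one thing at once and shows only a moderate spread.

Compound 4 is therefore expected to land near compound 2, with the step of a 1.6-fold higher number from compound 2 to compound 4 (0.20 log units; within the scatter) estimated as a small move toward a weaker number, likely within or just beyond the scatter. The estimate for compound 4 in this assay is 12000 nM, with a range from 4000 nM to 40000 nM.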

Compound 4, half-maximal inhibitory concentration: 52500 nM
Beside the measured number, compound 4's estimate is 4.4-fold (0.64 log units) below it, and the stated range ends below it.
By their numbers in this assay, from the lowest: compounds 2 and 1 (each within the scatter of the next); then compound 3; then compound 4.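

In this assay, within the data shown here, placing 4-(((prop-1-en-1-yl)carbonyl)amino)phenyl in place of 3-((vinylcarbonyl)amino)phenyl on a saturated chain carbon bound to an aromatic nitrogen gives a 6.9-fold higher number from compound 2 to compound 4 (0.84 log units; beyond the scatter), the first step that changes a single place. It shows that the number is sensitive to the group at this place, even though both groups hold one six-membered aromatic ring of carbon only and the same counts of double bonds, hydrogen-bond donors and acceptors. No available evidence explains the step.

The change alters both where the amide sits on the phenyl and what the carbonyl carries, so the compounds shown cannot divide the step between the two. A 4-((vinylcarbonyl)amino)phenyl or a 3-(((prop-1-en-1-yl)carbonyl)amino)phenyl group at the same place would separate these two parts.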